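The source may report more compounds than this note shows. Statements on the series, on what has been measured and on what is new or still open speak of the compounds shown alone.

Measured so far:
Compound 1 `CCOc1ccc(NCc2nc3cc(OC)ccc3[n+]([O-])c2-c2ccccc2)cc1`: 4.95 ug/mL
Compound 2 `COc1ccc2c(c1)[n+]([O-])c(C(=O)N=[N+]=[N-])c(C)[n+]2[O-]`: 3.61 ug/mL

In a functional assay on HepG2 cells (Homo sapiens) for inhibition, read by sulforhodamine B assay, with a stated time of 48 h (on this read-out lower numbers stand for stronger inhibition and higher numbers for weaker inhibition), compound 2 gives 3.61 ug/mL and compound 1 gives 4.95 ug/mL, and these two numbers lie within the scatter of each other. Compound 3 `COc1ccc2c(c1)[n+]([O-])c(NC(=O)OC(C)C)c(C)[n+]2[O-]` keeps the core of compound 2 and changes one group on an aromatic carbon: a group of 7 heavy atoms (4 carbon, 1 nitrogen, 2 oxygen; no ring) in place of a group of 5 heavy atoms (1 carbon, 3 nitrogen, 1 oxygen; no ring), on an aromatic carbon. Among the compounds with values here, no measured pair shows this change, so no step beyond the scatter is expected in this assay. The expected step is a 1.4-fold higher number from compound 2 to compound 3 (0.14 log units; within the scatter). For compound 3 the estimated value is 5 ug/mL, with an expected range from 1.8 ug/mL to 14 ug/mL.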

Compound 3, half-maximal inhibitory concentration: 6 ug/mL
Estimate against measurement, compound 3: 1.2-fold (0.08 log units) below; the measured number falls inside the stated range.
By their numbers in this assay, from the lowest: compounds 2, 1 and 3 (each within the scatter of the next).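

In this assay, within the data shown here, the position next to the ring nitrogen now has a first reading on the shared core: (isopropoxycarbonyl)amino in place of the earlier group gives a 1.7-fold higher number from compound 2 to compound 3 (0.22 log units; within the scatter) and stays within the scatter. This read-out therefore does not separate the two groups at this position, although the entering group adds a hydrogen-bond donor. Nothing measured here offers a reason for this result. As far as these compounds go, whether an amine, a carboxylic acid or a longer chain on the carbamate would read differently at this position stays open.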